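The source may report more compounds than this note shows. Statements on the series, on what has been measured and on what is new or still open speak of the compounds shown alone.

Measured so far: compound 1 `CC(=O)c1ccc(COc2ccc(-c3nn[nH]n3)cc2)c(C)c1O` and compound 2 `CCc1c(COc2ccc(-c3nn[nH]n3)cc2)ccc(C(C)=O)c1O`. In a functional assay on ileum (Cavia porcellus) for inhibition of cysteinyl leukotriene receptor (Homo sapiens) (a lower number here means a stronger inhibitor, a higher number a weaker inhibitor), compound 1 gives 100 nM; in this assay compound 2 gives 12.6 nM.

Compound 2 holds the lowest number of the two, set apart from compound 1 by a 7.9-fold lower number from compound 1 to compound 2 (0.90 log units; beyond the scatter). Compound 3 `CCc1c(COc2ccc(Cc3nnn[nH]3)cc2)ccc(C(C)=O)c1O` differs from compound 2 by (1H-tetrazol-5-yl)methyl in place of 2H-tetrazol-5-yl on an aromatic carbon. Within the data shown here, no measured step touches this part of the molecule; the single known step, a 7.9-fold lower number from compound 1 to compound 2 (0.90 log units; beyond the scatter), changes another part and offers no guide. The expectation for compound 3 therefore rests on compound 2 alone and carries a wide range: a step of a 2.4-fold higher number from compound 2 to compound 3 (0.38 log units; beyond the scatter) is expected, with compound 3 estimated at 30 nM, between 6 nM and 150 nM.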

Compound 3, half-maximal inhibitory concentration: 12.6 nM
For compound 3 the middle estimate is 2.4-fold (0.38 log units) above the measured one, within the range that was stated.
By their numbers in this assay, from the lowest: compounds 2 and 3 (each within the scatter of the next); then compound 1.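

In this assay, (1H-tetrazol-5-yl)methyl in place of 2H-tetrazol-5-yl on an aromatic carbon, para to a large group, gives no change at the digits printed from compound 2 to compound 3 (within the scatter). Among these compounds, this is the first reading at this position, and it shows that the extra carbon between the aromatic ring and the tetrazole ring can be added here without a step beyond the scatter. No available evidence bears on this result.

Still open, as far as these compounds go, is whether a longer chain carrying the tetrazole would also leave the number in this range. From the compounds shown here alone, whether a carboxylic acid could stand in place of the tetrazole at this position is also open.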